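The compounds below may be only part of what the source reports. "The series", "measured", "known", "first", "only" and "open" are said of these compounds alone.

Compound 1 `O=C(COc1ccc(/C=C2\SC(=O)NC2=O)cc1)Nc1ccc(F)cc1` was tested in a functional assay on PC-3 cells (Homo sapiens) for inhibition; on this read-out higher numbers stand for weaker inhibition of growth and lower numbers for stronger inhibition of growth. For compound 1 the result is a limit of the assay rather than a number, > 100000 nM. Compound 2 `O=C(COc1ccc(/C=C2\SC(=O)NC2=O)cc1)Nc1ccc(C(F)(F)F)cc1Cl`, which carries a different group on the same amide-type nitrogen, was tested in this assay as well. For compound 2 the outcome is again a limit, > 100000 nM. Both measured results thus sit at the limit of > 100000 nM in this assay, at which 2 of the 2 values shown sit, so compound 1 cannot be placed anywhere but at that boundary. Compound 3 `O=C(COc1ccc(/C=C2\SC(=O)NC2=O)cc1)Nc1c(Cl)cccc1Cl` differs from compound 1 in one place: 2,6-dichlorophenyl in place of 4-fluorophenyl on an amide-type nitrogen. Among the measured compounds shown here, no measured pair shows what such a change does in this assay. Because both known results sit at the limit of > 100000 nM in this assay, at which 2 of the 2 values shown sit, the expected step from compound 1 to compound 3 is a number no higher from compound 1 to compound 3 (the limit leaves the size open), that is, nothing beyond the scatter. Compound 3 is expected to give about 100000 nM in this assay, within a range from 30000 nM to 300000 nM, and most likely to be reported as a limit once more.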

Compound 3, concentration for 50% growth inhibition: > 100000 nM
Compound 3: only a limit was reported (the forecaster's own chance of this, stated with the estimate: 75%); the middle value sits exactly at the limit.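

Compound 1 and compound 3 both end at a limit of the assay, so no step can be read from the swap of 4-fluorophenyl for 2,6-dichlorophenyl: the limit of > 100000 nM in this assay, at which 3 of the 3 values shown sit. The compounds shown leave open whether the group on the amide-type nitrogen changes the result in this assay at all.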